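Nitrofuran Esters and Cell Toxicity: A New Amide

The source may hold more compounds than are shown below. What is called first, only, known or untested is meant among the compounds shown, and "the series" means these compounds.

The compounds measured so far:
- Compound 1, `CC(C)OC(=O)COC(=O)c1ccc([N+](=O)[O-])o1`, gives > 100000 nM in an ADME assay on HEK-293T cells (Homo sapiens) for cytotoxicity, read by MTT assay, with a stated time of 3 days; on this read-out lower numbers stand for higher toxicity in this test and higher numbers for lower toxicity in this test; this is a limit of the test, not a number.
- Compound 2, `O=C(COC(=O)c1ccc([N+](=O)[O-])o1)NC1CCc2ccccc21`, gives > 100000 nM in this assay; again a limit, not a number.
- Compound 3, `CC(C)(C)N(CCCc1ccccc1)C(=O)COC(=O)c1ccc([N+](=O)[O-])o1`, is reported in this assay only as "not active" (no number reported), with no number at all.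

All three share the same nitrofuran ester core, and none of them shows measurable harm to the cells. Compound 3 stands without a number of its own, and the two companions that do carry a result both sit at the edge of what the test can see (the limit of > 100000 nM in this assay, at which 2 of the 3 values shown sit). Among the measured compounds shown here, there is therefore no measured step in this assay from which to gauge how a change to the amide side of compound 3 would move the result.

Compound 4, `CC(C)(C)N(Cc1ccc(C(F)(F)F)cc1)C(=O)COC(=O)c1ccc([N+](=O)[O-])o1`, differs from compound 3 in one place: 4-(trifluoromethyl)phenyl in place of phenethyl on a saturated chain carbon bound to an amide-type nitrogen. For the measured compounds named here, with no measured step at hand, and with every companion sitting at the limit or reported without a number, the expected size of the step from compound 3 to compound 4 in this assay is none beyond the scatter, in neither direction. Compound 4 is thus estimated to give about 150000 nM, most likely between 50000 nM and 500000 nM, and quite possibly again only a limit rather than a number.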

Compound 4, half-maximal cytotoxic concentration: 36000 nM
Estimate against measurement, compound 4: 4.2-fold (0.62 log units) above; the whole stated range lies above it.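

Among the compounds shown here, compound 4 gives 36000 nM in this assay, but compound 3 is reported there only as "not active", with no number, so no step between these two compounds can be read. Still open is what replacing phenethyl with 4-(trifluoromethyl)phenyl does to the value on its own, and the results of the compounds held at the edge of the test remain limits rather than numbers: the limit of > 100000 nM in this assay, at which 2 of the 4 values shown sit.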